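Phenyl Added at the Chain Carbon: Expected Cytotoxicity

The compounds below may be only part of what the source reports. "The series", "measured", "known", "first", "only" and "open" are said of these compounds alone.

Measured compounds:
compound 1, `COCNc1n[n+]([O-])c2ccccc2[n+]1[O-]`: 4270 nM
compound 2, `[O-][n+]1nc(NCOCc2ccccc2)[n+]([O-])c2ccccc21`: 11900 nM
compound 3, `CCOCNc1n[n+]([O-])c2ccccc2[n+]1[O-]`: 7400 nM

In a functional assay on PC-3 cells (Homo sapiens) for cytotoxicity, read by MTT assay, with a stated time of 72 h (a higher number here means a weaker inhibitor, a lower number a stronger inhibitor), compound 1 gives 4270 nM, compound 2 gives 11900 nM and compound 3 gives 7400 nM. Compound 2 differs from compound 1 by phenyl in place of hydrogen on a saturated chain carbon bound to an oxygen on a saturated carbon, and this gave a 2.8-fold higher number from compound 1 to compound 2 (0.45 log units; beyond the scatter). Compound 3 differs from compound 1 by methyl in place of hydrogen on a saturated chain carbon bound to an oxygen on a saturated carbon, giving a 1.7-fold higher number from compound 1 to compound 3 (0.24 log units; within the scatter); between compound 2 and compound 3 the step is a 1.6-fold lower number from compound 2 to compound 3 (0.21 log units; within the scatter).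

Compound 4, `CC(OCNc1n[n+]([O-])c2ccccc2[n+]1[O-])c1ccccc1`, differs from compound 3 by phenyl in place of hydrogen on a saturated chain carbon bound to an oxygen on a saturated carbon and a saturated chain carbon. This is the same kind of change as between compound 1 and compound 2, but around the place the chain carbon is here also bound to a saturated chain carbon. Resting on a 2.8-fold higher number from compound 1 to compound 2 (0.45 log units; beyond the scatter), the step for compound 4 is expected to be about a 2.6-fold higher number from compound 3 to compound 4 (0.41 log units; beyond the scatter). Compound 4 is therefore estimated at 19000 nM, likely between 8000 nM and 45000 nM.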

Compound 4, half-maximal inhibitory concentration: 10700 nM
For compound 4 the middle estimate is 1.8-fold (0.25 log units) above the measured one, and the stated range covers the measured number.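

In this assay, phenyl in place of hydrogen on a saturated chain carbon gave a 1.4-fold higher number from compound 3 to compound 4 (0.16 log units; within the scatter), and this step agrees with the earlier one on the other core: the same change on two cores in this assay, a 2.8-fold higher number (0.45 log units; beyond the scatter) from compound 1 to compound 2 and a 1.4-fold higher number (0.16 log units; within the scatter) from compound 3 to compound 4, 1.9-fold (0.28 log units) apart, within the scatter of two such steps. Methyl in place of hydrogen on a saturated chain carbon gave a 1.1-fold lower number from compound 2 to compound 4 (0.05 log units; within the scatter), and it too agrees with its earlier counterpart: the same change on two cores in this assay, a 1.7-fold higher number (0.24 log units; within the scatter) from compound 1 to compound 3 and a 1.1-fold lower number (0.05 log units; within the scatter) from compound 2 to compound 4, 1.9-fold (0.28 log units) apart, within the scatter of two such steps. Going by these compounds alone, both changes therefore carry from one core to the other within the scatter, but this rests on only four compounds in one cell line and does not show a fixed step size, as only one phenyl step lies beyond the scatter.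

The compounds shown leave open whether a longer chain would follow the same steps. The same holds for an amine or a carboxylic acid at this chain carbon.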